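This account rests on a few compounds, and the source may have more. Where it says the series, first, only, none or still open, it means among the compounds named here.

Compound 3 `N#CC1=C(/N=C/c2ccccc2)N(c2ccccc2)C(=O)N2CCCCC(N3CCCC3)C12` gives the highest of the three numbers in a functional assay on the whole organism (strain albino) for inhibition, with Rattus norvegicus as the target, read by paw edema, with stated times of 1 h and 2 h, at a dose of 20 mmol/kg by the intraperitoneal route; a lower number here means less inhibition, a higher number more inhibition at the dose given (going by the name of the read-out): compound 3 reaches 75.9%. Compound 1 `N#CC1=C(NCC(=O)N2CCOCC2)N(c2ccccc2)C(=O)N2CCCCC(N3CCCC3)C12` gives 69.8%, a step that is a number 6.1 percentage points higher from compound 1 to compound 3 (within the scatter), and compound 2 `N#CC1=C(NCN2CCCCC2)N(c2ccccc2)C(=O)N2CCCCC(N3CCCC3)C12` gives 36.9%, a step that is a number 39 percentage points higher from compound 2 to compound 3 (beyond the scatter). Compound 4 `N#CC1=C(N)N(c2ccccc2)C(=O)N2CCCCC(N3CCCC3)C12` differs from compound 3 by one nitrogen atom in place of a group of 8 heavy atoms (7 carbon, 1 nitrogen; one six-membered aromatic ring of carbon only), on a double-bonded ring carbon. Neither measured step removes the whole group on that carbon, so both bear on the change only loosely. Because compound 2 sits at 36.9%, a fall is possible. Compound 4 is therefore expected to give about 55%, within 30% to 80%. The expected step is a number 20.9 percentage points lower from compound 3 to compound 4 (beyond the scatter).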

Compound 4, a percentage reported as inhibition, in the whole organism at one dose (the size of the read-out at that dose, not a potency): 86.9%
Compound 4: middle estimate off by 31.9 percentage points, on the low side; the whole stated range lies below it.
By their numbers in this assay, from the lowest: compound 2; then compounds 1 and 3 (each within the scatter of the next); then compound 4.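

In this assay, the unsubstituted amino group gives the highest number of the four compounds, and it does so with no group at all beyond that nitrogen. Amino stands above the phenyl-bearing group that leaves (a number 11 percentage points higher from compound 3 to compound 4 (beyond the scatter)), above ((morpholin-4-yl)carbonyl)methyl (a number 17.1 percentage points higher from compound 1 to compound 4 (beyond the scatter)) and above (piperidin-1-yl)methyl (a number 50 percentage points higher from compound 2 to compound 4 (beyond the scatter)). The earlier compounds shown here all carried a large group here, so only this result shows that each of the three stands below the bare amino group.

As far as these compounds go, whether a methyl or an acetyl group on this nitrogen would stay near amino remains open. Nothing available explains the gain.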